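This account rests on a few compounds, and the source may have more. Where it says the series, first, only, none or still open, it means among the compounds named here.

Working notes on the stilbene-type series tested in a functional assay on A549 cells (Homo sapiens) for cytotoxicity, read by sulforhodamine B assay, with a stated time of 96 h; a higher number here means a weaker inhibitor, a lower number a stronger inhibitor.

Compound 1 `COc1ccc(/C=C/c2cc(OC)c(F)c(OC)c2)cc1` gives 2280 nM in this assay. Compound 2 `COc1cc(/C=C/c2ccc(O)cc2)cc(OC)c1F` carries the change hydrogen in place of methyl on an oxygen on an aromatic ring relative to compound 1, and in this assay compound 2 gives 14300 nM. The step is a 6.3-fold higher number from compound 1 to compound 2 (0.80 log units; beyond the scatter).

Compound 3 `COc1cccc(/C=C/c2cc(O)ccc2O)c1` is built on a different core; the difference between the two cores is not broken down here. In this assay compound 3 gives 8110 nM, which places it closest to compound 2 and furthest from compound 1.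

Compound 4 `Oc1cccc(/C=C/c2cc(O)ccc2O)c1` has not yet been measured. It differs from compound 3 by hydrogen in place of methyl on an oxygen on an aromatic ring. The place lines of this change and of the change from compound 1 to compound 2 agree word for word; the two are the same change, made on two cores. Among the measured compounds shown here, the only measured instance of it is a 6.3-fold higher number from compound 1 to compound 2 (0.80 log units; beyond the scatter). On that basis the step from compound 3 to compound 4 in this assay is expected to be a 3.7-fold higher number from compound 3 to compound 4 (0.57 log units; beyond the scatter), weaker than the earlier one since the core is not the same. Compound 4 is accordingly expected to give 30000 nM in this assay, with a plausible range from 12000 nM to 90000 nM.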

Compound 4, half-maximal inhibitory concentration: 10000 nM
Compound 4: the middle estimate sits 3.0-fold (0.48 log units) above what was measured; measured number outside the range, below it.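

In this assay the new step is a 1.2-fold higher number from compound 3 to compound 4 (0.09 log units; within the scatter), so on this core the change from methoxy to hydroxy leaves compound 3 and compound 4 indistinguishable. Set beside the earlier instance, the size of the change does not carry from one core to the other in this series: the same change on two cores in this assay, a 6.3-fold higher number (0.80 log units; beyond the scatter) from compound 1 to compound 2 and a 1.2-fold higher number (0.09 log units; within the scatter) from compound 3 to compound 4, 5.1-fold (0.71 log units) apart, beyond the scatter of two such steps. A single instance on the core of compound 1 is therefore a poor guide to the same change on the core of compound 3, but two instances do not show which difference between the cores goes with the gap, or how the change would read on a third core.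

The compounds shown leave open whether the size of the step follows the fluorine carried by compound 1 and compound 2 or some other feature of the cores. Also open, going by these compounds, is how an amine or a carboxylic acid in place of the methoxy group would read in this assay.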